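Chain lengthening at the sulfur of compound 3

The source may report more compounds than this note shows. Statements on the series, on what has been measured and on what is new or still open speak of the compounds shown alone.

Compound 3 `CCCCSCC1C2CCC(O2)C1C/C=C\CCCC(=O)O` gives 1000 nM in a functional assay on a cell-free system (plasma) for inhibition of thromboxane A2 receptor (Homo sapiens) (a lower number here means a stronger inhibitor, a higher number a weaker inhibitor), the lowest of the three numbers measured. Compound 2 `CCSCC1C2CCC(O2)C1C/C=C\CCCC(=O)O` gives 5400 nM in this assay, and compound 1 `CCCCCCS(=O)(=O)CC1C2CCC(O2)C1C/C=C\CCCC(=O)O` gives 25000 nM. Compound 4 `CC/C=C/CCSCC1C2CCC(O2)C1C/C=C\CCCC(=O)O` differs from compound 3 by but-1-en-1-yl in place of ethyl on a saturated chain carbon, two bonds along the chain from a sulfur. For the measured compounds named here, the single step that bears on this change is a 5.4-fold lower number from compound 2 to compound 3 (0.73 log units; beyond the scatter), where lengthening the chain at the same carbon lowered the number. Compound 1 carries a different sulfur group, so its value offers no direct guide. Going by the values given here, a further lengthening is therefore expected to lower the number modestly, as a 2.0-fold lower number from compound 3 to compound 4 (0.30 log units; within the scatter), although the added double bond has no precedent in this set. Compound 4 is estimated at 500 nM in this assay, with a range from 150 nM to 2000 nM.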

Compound 4, half-maximal inhibitory concentration: 700 nM
The estimate for compound 4 lay 1.4-fold (0.15 log units) below the measured number; low and high end bracket the measured number.
By their numbers in this assay, from the lowest: compounds 4 and 3 (each within the scatter of the next); then compound 2; then compound 1.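

In this assay but-1-en-1-yl in place of ethyl on this saturated chain carbon gives a 1.4-fold lower number from compound 3 to compound 4 (0.15 log units; within the scatter) and so leaves compound 3 and compound 4 indistinguishable. The same group in place of hydrogen gives a 7.7-fold lower number from compound 2 to compound 4 (0.89 log units; beyond the scatter) and so keeps compound 4 clearly apart from compound 2. No measurement available here accounts for these steps.

From the compounds shown here alone, the contribution of the double bond remains open, as a saturated hexyl chain appears only in compound 1, which carries a different sulfur group. Also open, going by these compounds, is whether a phenyl or a hydroxyl at the chain end would hold the number.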